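Extending the Chain on Sulfur: Compound 1 to Compound 3

The source may report more compounds than this note shows. Statements on the series, on what has been measured and on what is new or still open speak of the compounds shown alone.

For the measured compounds named here, compound 1 `CCSc1n[nH]c(-n2[se]c3ccccc3c2=O)n1` is the only compound of this set with a plain number in an ADME assay on L929 cells (Mus musculus) for antiproliferative activity, read by CCK-8 assay, with a stated time of 48 h (on this read-out lower numbers stand for stronger inhibition and higher numbers for weaker inhibition), where compound 1 gives 35200 nM. Compound 2 `Cc1cccc(CSc2n[nH]c(-n3[se]c4ccccc4c3=O)n2)c1` carries a 3-methylphenyl in place of methyl on a saturated chain carbon bound to a sulfur. In this assay compound 2 reaches only the limit of the measurement, > 50000 nM, which is not a number. The step of an at least 1.4-fold higher number from compound 1 to compound 2 (0.15 log units; that floor lies within the scatter) therefore has a floor within the usual scatter, and its true size stays hidden behind (the limit of > 50000 nM in this assay, at which 1 of the 2 values shown sits). Compound 3 `CCCCCSc1n[nH]c(-n2[se]c3ccccc3c2=O)n1` has not yet been measured in this assay. It differs from compound 1 by propyl in place of hydrogen on a saturated chain carbon, two bonds along the chain from a sulfur. Going by the values given here, the one measured step also enlarges the group on the chain carbon bound to a sulfur, yet its limit offers little guidance for a propyl extension. The step of a 1.1-fold higher number from compound 1 to compound 3 (0.06 log units; within the scatter) is therefore expected to stay within the scatter, with a real chance that compound 3 is reported only as a limit. The estimated value for compound 3 in this assay is 40000 nM, with a range from 15000 nM to 110000 nM.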

Compound 3, half-maximal inhibitory concentration: 33500 nM
Estimate against measurement, compound 3: 1.2-fold (0.08 log units) above; the range from low to high includes it.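

For the compounds shown here, compound 3 gives this position a second plain number in this assay, so a step here can be read as a number for the first time, and adding propyl two bonds along the chain from a sulfur gives a 1.1-fold lower number from compound 1 to compound 3 (0.02 log units; within the scatter). The ethylsulfanyl and pentylsulfanyl compounds therefore cannot be told apart on this read-out, and within these two compounds the longer saturated chain shows no measurable effect. The step that puts butyl in place of 3-methylphenyl on the chain carbon bound to a sulfur reads an at least 1.4-fold lower number from compound 2 to compound 3 (0.17 log units; that floor lies within the scatter), but this is only a floor, and its true size stays hidden because one end of it is a limit and not a number: the limit of > 50000 nM in this assay, at which 1 of the 3 values shown sits.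

The compounds shown leave open whether a still longer chain, such as octyl, would stay level with these two values or move clear of the scatter. They also leave open what an amine or a carboxylic acid at the end of the chain would do, and whether a plain phenyl on the chain carbon bound to a sulfur would give a number instead of a limit.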